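The source may report more compounds than this note shows. Statements on the series, on what has been measured and on what is new or still open speak of the compounds shown alone.

Two compounds carry the shared core: compound 1 `CN(C)c1cccc(OCCCn2cnc(-c3ccccc3)c2)c1NC(=O)NC1CCCCC1` and compound 2 `CN(C)c1cccc(OCCCn2cnc(-c3ccccc3)c2)c1NC(=O)NC1CCCC1`. Among the measured compounds shown here, in an assay for inhibition of acyl-CoA:cholesterol acyltransferase (Oryctolagus cuniculus), using microsomes (on this read-out lower numbers stand for stronger inhibition and higher numbers for weaker inhibition), compound 1 gives 73 nM, and compound 2 gives 240 nM, the higher of the two numbers; the one known step, a 3.3-fold higher number from compound 1 to compound 2 (0.52 log units; beyond the scatter), concerns only the ring on the amide-type nitrogen. For the measured compounds named here, compound 3 `CCCCCC(=O)Nc1c(OCCCn2cnc(-c3ccccc3)c2)cccc1N(C)C` differs from compound 2 by pentyl in place of cyclopentylamino on a carbonyl carbon, a change that no measured step addresses. With the urea replaced by an amide and one hydrogen-bond donor gone, a modest weakening is expected, a 1.9-fold higher number from compound 2 to compound 3 (0.27 log units; within the scatter). Compound 3 is therefore estimated at 450 nM, within 110 nM to 1800 nM.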

Compound 3, half-maximal inhibitory concentration: 200 nM
For compound 3 the middle estimate is 2.3-fold (0.35 log units) above the measured one; measured number inside the range.
By their numbers in this assay, from the lowest: compound 1; then compounds 3 and 2 (each within the scatter of the next).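

In this assay the change from cyclopentylamino to pentyl on the carbonyl carbon is a 1.2-fold lower number from compound 2 to compound 3 (0.08 log units; within the scatter) and so removes the ring and the hydrogen-bond donor together without a shift that stands out from the scatter. Set against the cyclohexylamino group, the same pentyl gives a 2.7-fold higher number from compound 1 to compound 3 (0.44 log units; beyond the scatter) and so does not match compound 1. No evidence on the reason for either result is available. As far as these compounds go, what the ring and the donor each contribute alone remains open. So does whether a longer chain than pentyl, or a cyclohexyl on the carbonyl carbon, would match compound 1.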